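Para-substituent swaps on the octadecyl thiazolidine carboxamides

This account rests on a few compounds, and the source may have more. Where it says the series, first, only, none or still open, it means among the compounds named here.

Measured compounds:
compound 1 `CCCCCCCCCCCCCCCCCCNC(=O)[C@@H]1CSC(c2ccc(OC)cc2)N1`: 1500 nM
compound 2 `CCCCCCCCCCCCCCCCCCNC(=O)[C@@H]1CSC(c2cc(OC)c(OC)c(OC)c2)N1`: 480 nM
compound 3 `CCCCCCCCCCCCCCCCCCNC(=O)[C@@H]1CSC(c2ccc(N(C)C)cc2)N1`: 1100 nM

All three share one core and differ only in the aryl group on the saturated ring carbon. In a functional assay on PPC-1 cells (Homo sapiens) for antiproliferative activity, read by sulforhodamine B assay (a higher number here means a weaker inhibitor, a lower number a stronger inhibitor), compound 2 gives 480 nM, the lowest number of the three; compound 3 gives 1100 nM, the second highest, and compound 1 gives 1500 nM. The step of a 1.4-fold lower number from compound 1 to compound 3 (0.13 log units; within the scatter) lies within the scatter, while a 2.3-fold higher number from compound 2 to compound 3 (0.36 log units; beyond the scatter) and a 3.1-fold lower number from compound 1 to compound 2 (0.49 log units; beyond the scatter) lie beyond it.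

Compound 4 `CCCCCCCCCCCCCCCCCCNC(=O)[C@@H]1CSC(c2ccc(OCC)cc2)N1` is not yet measured. Relative to compound 3 it carries ethoxy in place of dimethylamino on an aromatic carbon. Among the compounds with values here, the only measured step touching that aromatic carbon, a 1.4-fold lower number from compound 1 to compound 3 (0.13 log units; within the scatter), is within the scatter, so an exchange of one such group for another has so far not moved the number. Within the data shown here, no measured pair shows methoxy against ethoxy. Compound 4 is therefore expected to lie close to compound 3, with an expected step of a 1.2-fold higher number from compound 3 to compound 4 (0.07 log units; within the scatter). The estimate for compound 4 in this assay is 1300 nM, within a range of 600 nM to 2800 nM.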

Compound 4, half-maximal inhibitory concentration: 4400 nM
Compound 4: middle estimate off by 3.4-fold (0.53 log units), on the low side; the whole stated range lies below it.
By their numbers in this assay, from the lowest: compound 2; then compounds 3 and 1 (each within the scatter of the next); then compound 4.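

In this assay the group on the aromatic carbon para to a large group proves not to be freely exchangeable: ethoxy in place of dimethylamino gives a 4.0-fold higher number from compound 3 to compound 4 (0.60 log units; beyond the scatter), although the earlier exchange of methoxy for dimethylamino stayed within the scatter. Methyl in place of hydrogen on the methoxy group is enough to give a 2.9-fold higher number from compound 1 to compound 4 (0.47 log units; beyond the scatter), and the 4-ethoxyphenyl group in place of 3,4,5-trimethoxyphenyl gives a 9.2-fold higher number from compound 2 to compound 4 (0.96 log units; beyond the scatter), the widest step in the series. No evidence at hand accounts for these steps.

On these data alone, whether a longer chain such as propoxy moves the number further in the same direction remains open. So does the effect of a hydroxyl group or a primary amine on that aromatic carbon.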